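Dichlorophenyl Hydrazone in the Cytotoxicity Series

The source may hold more compounds than are shown below. What is called first, only, known or untested is meant among the compounds shown, and "the series" means these compounds.

Of the compounds shown here, three sharing one core have been measured in an ADME assay on THP-1 cells (Homo sapiens) for cytotoxicity; on this read-out lower numbers stand for stronger inhibition and higher numbers for weaker inhibition. Compound 1 `COc1ccccc1-c1nnc(-c2ccc(C(=O)N/N=C/c3ccc(O)c(O)c3)cc2)o1` gives 100000 nM; compound 2 `COc1ccccc1-c1nnc(-c2ccc(C(=O)N/N=C/c3ccccc3O)cc2)o1` gives 207000 nM; compound 3 `COc1ccccc1-c1nnc(-c2ccc(C(=O)N/N=C/c3cccnc3)cc2)o1` gives 167000 nM. Compound 3 has the second highest of the three numbers, within the scatter of both neighbours: the step of a 1.7-fold higher number from compound 1 to compound 3 (0.22 log units; within the scatter) and the step of a 1.2-fold lower number from compound 2 to compound 3 (0.09 log units; within the scatter) are both small. For the measured compounds named here, only the step of a 2.1-fold higher number from compound 1 to compound 2 (0.32 log units; beyond the scatter) reaches beyond the scatter, and only modestly.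

Compound 4 `COc1ccccc1-c1nnc(-c2ccc(C(=O)N/N=C/c3ccc(Cl)cc3Cl)cc2)o1` is not yet measured. Its change from compound 3 is 2,4-dichlorophenyl in place of pyridin-3-yl on a carbon with a double bond to nitrogen. Every measured step in this assay swaps the aryl group on that same carbon, so all three bear on the question, and together they show that such swaps have moved the number little. On that basis the step of a 1.0-fold lower number from compound 3 to compound 4 (0.02 log units; within the scatter) is expected to stay within the scatter, with no clear direction.

Compound 4 is therefore estimated at 160000 nM in this assay, with a range from 70000 nM to 360000 nM.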

Compound 4, half-maximal inhibitory concentration: 78800 nM
The estimate for compound 4 lay 2.0-fold (0.31 log units) above the measured number; low and high end bracket the measured number.
By their numbers in this assay, from the lowest: compounds 4, 1, 3 and 2 (each within the scatter of the next, the first and the last beyond it).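

In this assay, for the compounds shown here, the aryl group on the carbon with a double bond to nitrogen now shows a clearer effect than the earlier compounds did, since 2,4-dichlorophenyl, a ring of carbon only, gives a 2.1-fold lower number from compound 3 to compound 4 (0.33 log units; beyond the scatter) and a 2.6-fold lower number from compound 2 to compound 4 (0.42 log units; beyond the scatter) as two further modest steps beyond the scatter. The chlorinated ring does not stand apart from every other group at this position, however, for the change from 3,4-dihydroxyphenyl gives only a 1.3-fold lower number from compound 1 to compound 4 (0.10 log units; within the scatter) and so stays within the scatter, which means two quite different aryl groups can give numbers that cannot be told apart here. The data offer no measured basis for explaining these differences.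

The compounds shown leave open whether the step from pyridin-3-yl belongs to both chlorine atoms together or could be reached with a single chlorine on the phenyl ring. They also leave open how this position responds to a group outside the aryl family, such as an amine, a carboxylic acid or a longer alkyl chain on the same carbon, and whether any such group would move the number further than these modest steps.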